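Swapping carboxy for hydroxymethyl on the amide side chain

The compounds below may be only part of what the source reports. "The series", "measured", "known", "first", "only" and "open" are said of these compounds alone.

Compound 1 `CCn1c(C(=O)NCCCN(C)C)ccc1C(CC)(CC)c1ccc(OCCC(O)(CC)CC)c(C)c1` gives 3350 nM
Compound 2 `CCOC(=O)CN(C)C(=O)c1ccc(C(CC)(CC)c2ccc(OCCC(O)(CC)CC)c(C)c2)n1CC` gives 3210 nM
Compound 3 `CCn1c(C(=O)NC(C)C(=O)O)ccc1C(CC)(CC)c1ccc(OCCC(O)(CC)CC)c(C)c1` gives 19700 nM

In a functional assay on MCF7 cells (Homo sapiens) for antiproliferative activity, read by MTT assay, with a stated time of 48 h (a higher number here means a weaker inhibitor, a lower number a stronger inhibitor), compound 3 stands highest of the three, making it the weakest inhibitor here. Compound 4 `CCn1c(C(=O)NC(C)CO)ccc1C(CC)(CC)c1ccc(OCCC(O)(CC)CC)c(C)c1` changes one group: hydroxymethyl in place of carboxy on a saturated chain carbon bound to an amide-type nitrogen and a saturated chain carbon with hydroxymethyl in place of carboxy on a saturated chain carbon bound to an amide-type nitrogen and a saturated chain carbon. Within the data shown here, no measured step makes this exact swap. The nearest evidence is a 5.9-fold higher number from compound 1 to compound 3 (0.77 log units; beyond the scatter) and a 6.1-fold higher number from compound 2 to compound 3 (0.79 log units; beyond the scatter) where compound 3 alone carries carboxy. Losing carboxy should therefore lower the number in this assay and probably recover most of that gap. The expected change is a 3.9-fold lower number from compound 3 to compound 4 (0.60 log units; beyond the scatter) as a rough estimate. For compound 4 the estimated value is 5000 nM with 2000 nM to 13000 nM as its expected range.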

Compound 4, half-maximal inhibitory concentration: 12600 nM
The estimate for compound 4 lay 2.5-fold (0.40 log units) below the measured number, and the stated range covers the measured number.
By their numbers in this assay, from the lowest: compounds 2 and 1 (each within the scatter of the next); then compounds 4 and 3 (each within the scatter of the next).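

Replacing carboxy with hydroxymethyl at this place in this assay gives a 1.6-fold lower number from compound 3 to compound 4 (0.19 log units; within the scatter) and so does not separate these two groups. Compound 4 also stays apart from the other two compounds, with a 3.9-fold higher number from compound 2 to compound 4 (0.59 log units; beyond the scatter) and a 3.8-fold higher number from compound 1 to compound 4 (0.58 log units; beyond the scatter), so carboxy alone does not account for the gap first seen with compound 3. The data offer no measured explanation for this. Still open, going by these compounds, is whether an amine or a methyl ester in this same place would close that gap. A longer chain carrying the hydroxyl group is equally untested by these compounds.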